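Removing the Outer Aryl Ring from a Benzylic Amide

The source may report more compounds than this note shows. Statements on the series, on what has been measured and on what is new or still open speak of the compounds shown alone.

Of the compounds shown here, three sharing one core have been measured in an assay on isolated protein with Bile acid receptor (Homo sapiens) as the target; on this read-out higher numbers stand for an effect only at larger amounts of compound and lower numbers for an effect already at smaller amounts. Compound 1 `COC(=O)/C=C/c1cccc(N(Cc2ccc(/C=C/c3ccccn3)cc2)C(=O)C2CCCCC2)c1` gives 309 nM. Compound 2 `COC(=O)/C=C/c1cccc(N(Cc2ccc(-c3ccc(OC)cc3)cc2)C(=O)C2CCCCC2)c1` gives 89 nM, and compound 3 `COC(=O)/C=C/c1cccc(N(Cc2ccc(-c3cccc(Cl)c3)cc2)C(=O)C2CCCCC2)c1` gives 94 nM. Among these three numbers compound 3 stands second highest: its nearest neighbour is compound 2, a gap within the scatter, while the furthest is compound 1, a gap beyond the scatter.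

The measured steps were a 3.5-fold lower number from compound 1 to compound 2 (0.54 log units; beyond the scatter) and a 3.3-fold lower number from compound 1 to compound 3 (0.52 log units; beyond the scatter), whereas a 1.1-fold higher number from compound 2 to compound 3 (0.02 log units; within the scatter). So swapping one outer ring for another changed little, but the nature of the outer group mattered.

Compound 4 `COC(=O)/C=C/c1cccc(N(Cc2ccccc2)C(=O)C2CCCCC2)c1` goes further: hydrogen in place of 3-chlorophenyl on an aromatic carbon. Among the compounds with values here, no measured step removes the outer group altogether, so the size of this change is untested. The expectation is a 16-fold higher number from compound 3 to compound 4 (1.20 log units; beyond the scatter), a rise in this assay. Compound 4 is therefore estimated at 1500 nM, between 400 nM and 6000 nM.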

Compound 4, half-maximal effective concentration: > 1000 nM
Compound 4: only a limit was reported; the forecaster's own chance of this, stated with the estimate: 15%; the middle value does not contradict the limit.
By their numbers in this assay, from the lowest: compounds 2 and 3 (each within the scatter of the next); then compound 1. At a limit, above all of these: compound 4.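

For compound 4 the read-out is a limit and not a number: the limit of > 1000 nM in this assay, at which 1 of the 4 values shown sits. Even so, the steps are clear: an at least 10-fold higher number from compound 3 to compound 4 (1.02 log units; beyond the scatter), an at least 11-fold higher number from compound 2 to compound 4 (1.05 log units; beyond the scatter) and an at least 3.2-fold higher number from compound 1 to compound 4 (0.51 log units; beyond the scatter). The earlier compounds shown here showed only what happens when one outer group replaces another, whereas this change shows that having any of these outer groups on this aromatic carbon, para to a large group, gives a lower number than bare hydrogen, and that this holds even for the 2-(pyridin-2-yl)ethenyl group of compound 1.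

Still open, going by these compounds, is whether a full outer ring is needed at all, or whether a single chlorine or a methyl on this carbon would do as well. On these data alone, it is also open whether a cyclohexyl ring, or an outer ring carrying an amine or a carboxylic acid, would keep the number near that of compound 3.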